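A few compounds are considered here, and "the series" means these few. Any claim that something is new, unique, unknown or untested is made for them only; others in the source may bear on it.

Compound 1 `CC(C)[C@H](NC(=O)CN(c1nc(Cl)nc2[nH]cnc12)C1CC1)C(=O)O` and compound 2 `CSCC[C@H](NC(=O)CN(c1nc(Cl)nc2[nH]cnc12)C1CC1)C(=O)O` share one core, while compound 3 `CSCC[C@H](NC(=O)CN(c1ncnc2c1ncn2C1CCCCO1)C1CC1)C(=O)OCc1ccccc1` and compound 4 `CC(C)[C@H](NC(=O)CN(c1ncnc2c1ncn2C1CCCCO1)C1CC1)C(=O)OCc1ccccc1` share another; the difference between the two cores is not broken down here. In a functional assay on the whole organism (Tail, strain ICR) with Mus musculus as the target, in the tail flick test, with a stated time of 120 min, at a dose of 25 umol/kg by the oral route (a lower number here means a weaker effect, a higher number a stronger effect of the compound at the dose given), compound 1 gives 17.1%, compound 2 gives 5.67%, and compound 3 gives 28.7%, the highest of the three. The change isopropyl in place of 2-(methylsulfanyl)ethyl on a saturated chain carbon bound to an amide-type nitrogen and a carbonyl carbon produced a step of a number 11.4 percentage points higher from compound 2 to compound 1 (beyond the scatter). The same change, on the other core, appears as isopropyl in place of 2-(methylsulfanyl)ethyl on a saturated chain carbon bound to an amide-type nitrogen and a carbonyl carbon. Going by the values given here, for compound 4 a step of a number 10.3 percentage points higher from compound 3 to compound 4 (beyond the scatter) in this assay is expected, close to the earlier one, because the one measured instance of this change gave a number 11.4 percentage points higher from compound 2 to compound 1 (beyond the scatter). Compound 4 is therefore estimated at 39%, with a range from 22% to 56%.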

Compound 4, a percentage reported as activity, at one dose (the size of the read-out at that dose, not a potency): 25.8%
The estimate for compound 4 lay 13.2 percentage points above the measured number; the measured number falls inside the stated range.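

In this assay, isopropyl in place of 2-(methylsulfanyl)ethyl on the second core gives a number 2.9 percentage points lower from compound 3 to compound 4 (within the scatter). The change therefore does not carry over at one size from one core to the other in this series: the same change on two cores in this assay, a number 11.4 percentage points higher (beyond the scatter) from compound 2 to compound 1 and a number 2.9 percentage points lower (within the scatter) from compound 3 to compound 4, 14.3 percentage points apart, beyond the scatter of two such steps

This rests on a single pair on each core, at one dose and one time, and it does not show which feature of the two cores goes with the gap, or how the change would behave on any further core. The compounds shown leave open how other groups would fare on a saturated chain carbon bound to an amide-type nitrogen and a carbonyl carbon, such as a longer alkyl chain or a chain carrying an amine. They also leave open whether either core would keep the order of its pair with such groups.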